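The source may report more compounds than this note shows. Statements on the series, on what has been measured and on what is new or still open speak of the compounds shown alone.

Compound 2 `CCC1=C(O)c2c(oc(-c3ccc(Br)cc3)cc2=O)C(CC)(CC)C1=O` gives 15.7 uM in a functional assay on KBVIN cells (Homo sapiens) for antiproliferative activity, read by sulforhodamine B assay, with a stated time of 3 days; on this read-out higher numbers stand for an effect only at larger amounts of compound and lower numbers for an effect already at smaller amounts. Among the compounds with values here, compound 1 `CCC1=C(O)c2c(oc(-c3ccc(OC(F)(F)F)cc3)cc2=O)C(CC)(CC)C1=O` gives 9.95 uM in this assay; the only measured step, a 1.6-fold higher number from compound 1 to compound 2 (0.20 log units; within the scatter), separates these two, so they are not distinguishable within the scatter. Compound 3 `CCC1=C(O)c2c(oc(-c3cc(C)c(C)cc3C)cc2=O)C(CC)(CC)C1=O` is not yet measured. The change is 2,4,5-trimethylphenyl in place of 4-bromophenyl on an aromatic carbon. That single measured step also replaced a group on an aromatic carbon and stayed within the scatter, so no step beyond the scatter in this assay is expected here. Compound 3 is expected to give 15 uM, between 5 uM and 45 uM, which is estimated as a 1.0-fold lower number from compound 2 to compound 3 (0.02 log units; within the scatter).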

Compound 3, concentration for half-maximal effect: 4.37 uM
Compound 3: the middle estimate sits 3.4-fold (0.54 log units) above what was measured; the whole stated range lies above it.
By their numbers in this assay, from the lowest: compound 3; then compounds 1 and 2 (each within the scatter of the next).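

In this assay this position on the shared core responds to the group placed on it: 2,4,5-trimethylphenyl in place of 4-bromophenyl gives a 3.6-fold lower number from compound 2 to compound 3 (0.56 log units; beyond the scatter), a modest step, whereas the earlier replacement stayed within the scatter. Both groups keep one six-membered aromatic ring of carbon only, so the step comes with a change of substituents on that ring. No measurement shown here explains the step.

As far as these compounds go, it remains open whether a single methyl, as in 4-methylphenyl, would give a similar step or all three methyl groups are needed. From the compounds shown here alone, how an amine or a carboxylic acid on that ring would behave also remains open.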